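From 3-(dipropylamino)propyl to 4-(dipropylamino)butyl

The source may hold more compounds than are shown below. What is called first, only, known or untested is meant among the compounds shown, and "the series" means these compounds.

Measured in a functional assay on PC-3 cells (Homo sapiens) for antiproliferative activity, read by WST assay, with a stated time of 3 days; a higher number here means a weaker inhibitor, a lower number a stronger inhibitor:
Compound 1 `CCC(C)Oc1c(-c2cc(OC)c(OC)c(OC)c2)oc2ccccc2c1=O`: 38600 nM
Compound 2 `CCCN(CCC)CCCOc1c(-c2cc(OC)c(OC)c(OC)c2)oc2ccccc2c1=O`: 16800 nM

Compound 2 holds the lower of the two numbers, which makes it the stronger inhibitor so far. Going by the values given here, the only measured step is a 2.3-fold lower number from compound 1 to compound 2 (0.36 log units; beyond the scatter). It put 3-(dipropylamino)propyl in place of sec-butyl on an oxygen on an aromatic ring, a modest gain.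

Compound 3 `CCCN(CCC)CCCCOc1c(-c2cc(OC)c(OC)c(OC)c2)oc2ccccc2c1=O` carries 4-(dipropylamino)butyl where compound 2 has 3-(dipropylamino)propyl: (dipropylamino)methyl in place of dipropylamino on a saturated chain carbon, three bonds along the chain from an oxygen on an aromatic ring. Among the compounds with values here, the measured step swapped a whole group, and no measured pair tests chain length alone, so it offers only weak guidance. Compound 2, at 16800 nM, remains the best anchor, and no shift beyond the scatter is expected in this assay.

The estimated step is a 1.1-fold lower number from compound 2 to compound 3 (0.05 log units; within the scatter). For compound 3 the expected value is 15000 nM, with an estimated range of 6500 nM to 35000 nM.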

Compound 3, half-maximal inhibitory concentration: 11600 nM
The estimate for compound 3 lay 1.3-fold (0.11 log units) above the measured number; the measured number falls inside the stated range.
By their numbers in this assay, from the lowest: compounds 3 and 2 (each within the scatter of the next); then compound 1.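

In this assay, the pair gives the first test of chain length alone at this oxygen: 4-(dipropylamino)butyl in place of 3-(dipropylamino)propyl gives a 1.4-fold lower number from compound 2 to compound 3 (0.16 log units; within the scatter), so the two chains cannot be told apart here. Set against sec-butyl on the same oxygen, 4-(dipropylamino)butyl gives a 3.3-fold lower number from compound 1 to compound 3 (0.52 log units; beyond the scatter), so this chain, like the one in compound 2, stands clear of compound 1. No measured evidence bears on why these numbers fall as they do.

Still open, from the compounds shown here alone, is how a shorter chain such as 2-(dipropylamino)ethyl or a chain longer than 4-(dipropylamino)butyl would compare. Also open, going by these compounds, is whether a different end group on the same chain, such as dimethylamino or piperidine, would move the number beyond the scatter.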